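Trimming the chloromethyl from compound 2

The compounds below may be only part of what the source reports. "The series", "measured", "known", "first", "only" and "open" are said of these compounds alone.

Compound 2: `NCCOc1ccc(/C(=C(\CCCl)c2ccccc2)c2ccc(O)cc2)cc1` — 143 nM
Compound 1: `CC/C(=C(/c1ccc(O)cc1)c1ccc(CCCN)cc1)c1ccc(O)cc1` — 491 nM
Compound 3: `CC/C(=C(/c1ccc(O)cc1)c1ccc(OCCO)cc1)c1ccccc1` — 30500 nM

In an assay on isolated protein for inhibition of Aromatase (Homo sapiens), read by fluorescence, with a stated time of 30 min (a lower number here means a stronger inhibitor, a higher number a weaker inhibitor), compound 2 gives 143 nM, the lowest of the three numbers. Compound 1 gives 491 nM, a gap beyond the scatter, and compound 3 gives 30500 nM, far weaker still. Among the compounds with values here, no single-change step between measured compounds is available, so the move to compound 4, `C/C(=C(/c1ccc(O)cc1)c1ccc(OCCN)cc1)c1ccccc1`, rests on the change itself: hydrogen in place of chloromethyl on a saturated chain carbon bound to a double-bonded chain carbon. The chain grows shorter, from 2-chloroethyl to methyl. Compound 1 and compound 3, both carrying an ethyl at that place, are weaker than compound 2, so a modest loss is expected from compound 2 to compound 4, a 3.5-fold higher number from compound 2 to compound 4 (0.54 log units; beyond the scatter). Compound 4 is therefore estimated at 500 nM, within 150 nM to 1800 nM.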

Compound 4, half-maximal inhibitory concentration: 337 nM
Beside the measured number, compound 4's estimate is 1.5-fold (0.17 log units) above it; the range from low to high includes it.
By their numbers in this assay, from the lowest: compound 2; then compounds 4 and 1 (each within the scatter of the next); then compound 3.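

In this assay, hydrogen in place of chloromethyl on a saturated chain carbon bound to a double-bonded chain carbon gives a 2.4-fold higher number from compound 2 to compound 4 (0.37 log units; beyond the scatter). Within the data shown here, this is the first single-change reading at this position, and it shows that shortening 2-chloroethyl to methyl costs only a modest loss, so the chlorine-bearing chain is not needed for inhibition at this level. Nothing available explains the size of this step.

The ethyl of compound 1 and compound 3 cannot be placed on this step, as both compounds also differ elsewhere. As far as these compounds go, whether a 2-fluoroethyl, a 2-hydroxyethyl or a longer propyl chain at this position would match compound 2 remains open.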